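A few compounds are considered here, and "the series" means these few. Any claim that something is new, unique, unknown or untested is made for them only; others in the source may bear on it.

Two compounds built on the same core have so far been run in an ADME assay on microsomes from liver (Homo sapiens) for metabolic stability; a lower number here means slower removal, a higher number faster removal of the compound. Compound 1 `C[C@@H](NC(=O)Cn1nnc2ccccc2c1=O)c1ccc(Cl)cc1` gives < 9.9 mL/min/kg, which is a limit of the assay rather than a number. Compound 2 `Cc1cccc([C@H](C)NC(=O)Cn2nnc3ccccc3c2=O)c1` gives 11 mL/min/kg in this assay. Among the compounds with values here, compound 2 thus holds the only full number recorded in this assay. The remaining entry, that of compound 1, sits at the limit of < 9.9 mL/min/kg in this assay, at which 1 of the 2 values shown sits. Within the data shown here, no step between measured compounds is available, as compounds 1 and 2 differ in more than one place, and the pair shows only that one result is a limit and the other a number.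

Compound 3 `Cc1ccc([C@H](C)NC(=O)Cn2nnc3ccccc3c2=O)cn1` has not yet been measured in this assay. It differs from compound 2 by 6-methylpyridin-3-yl in place of 3-methylphenyl on a saturated chain carbon bound to an amide-type nitrogen and a saturated chain carbon. Among the measured compounds shown here, no measured step of this kind is on hand, so the expectation rests on compound 2 alone. The step of a 1.2-fold lower number from compound 2 to compound 3 (0.09 log units; within the scatter) is expected to be small and downward, staying within the usual scatter of repeated measurements. Compound 3 is estimated at 9 mL/min/kg in this assay, with a range from 5 mL/min/kg to 16 mL/min/kg.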

Compound 3, clearance: < 9.9 mL/min/kg
Compound 3: no number, only a limit; the forecaster's own chance of this, stated with the estimate: 45%; the middle value does not contradict the limit.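

Within the data shown here, this is the first step that can be read in this assay: 6-methylpyridin-3-yl in place of 3-methylphenyl on a saturated chain carbon bound to an amide-type nitrogen and a saturated chain carbon gives an at least 1.1-fold lower number from compound 2 to compound 3 (0.04 log units; that floor lies within the scatter). Compound 3 gives < 9.9 mL/min/kg, which is a limit of the assay and not a number, so only a floor for the step is known and its true size remains hidden. At this place, then, a six-membered aromatic ring with a hetero atom does not lift the number away from that limit, which now holds most of the results: the limit of < 9.9 mL/min/kg in this assay, at which 2 of the 3 values shown sit.

The compounds shown leave open how far compound 3 really lies from compound 2, and whether the outcome would carry over to other groups at this place, such as a pyrimidin-5-yl ring or a 6-methoxypyridin-3-yl group. They also leave open what part the methyl on the ring plays, a question that a plain pyridin-3-yl group in the same place would address.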